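The compounds below may be only part of what the source reports. "The series", "measured", "known", "first", "only" and "open" are said of these compounds alone.

Compounds measured so far:

compound 1 `CC[C@H](C)C(N)c1cc(C(F)(F)F)ccc1N1CCN(C(=O)CCc2ccc(Cl)cc2Cl)CC1` – 75 nM
compound 2 `NC(COCc1ccccc1)c1cc(F)ccc1N1CCN(C(=O)CCc2ccc(Cl)cc2Cl)CC1` – 1000 nM
compound 3 `COc1ccc(OC)c(CCC(=O)N2CCN(c3ccc(C(F)(F)F)cc3[C@@H](N)CC(C)C)CC2)c1` – 2500 nM

In an assay on HEK293 cells for displacement of a labelled ligand from Melanocortin receptor 4 (Homo sapiens) (a lower number here means a stronger inhibitor, a higher number a weaker inhibitor), compound 1 gives 75 nM, the lowest of the three numbers. Its nearest neighbour, compound 2, gives 1000 nM, a gap beyond the scatter, and the furthest, compound 3, gives 2500 nM, also beyond the scatter. Compound 1 is therefore the strongest inhibitor among the measured set.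

Compound 4 `CC(C)C[C@H](NC(=O)CN)c1cc(C(F)(F)F)ccc1N1CCN(C(=O)CCc2ccc(Cl)cc2Cl)CC1` has not yet been measured in this assay. It differs from compound 1 in one place: 1-(((aminomethyl)carbonyl)amino)-3-methylbutyl in place of 1-amino-2-methylbutyl on an aromatic carbon. The 1-amino-2-methylbutyl group with its single hydrogen-bond donor and acceptor gives way to a larger 1-(((aminomethyl)carbonyl)amino)-3-methylbutyl group carrying two of each.

For the measured compounds named here, no step between measured compounds covers this change, so the expectation rests on compound 1 alone. The account expects a modest weakening, a step of a 2.7-fold higher number from compound 1 to compound 4 (0.43 log units; beyond the scatter), with compound 4 estimated at 200 nM in this assay, within a range from 50 nM to 800 nM.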

Compound 4, inhibition constant: 19 nM
Compound 4: the middle estimate sits 11-fold (1.02 log units) above what was measured; the whole stated range lies above it.
By their numbers in this assay, from the lowest: compound 4; then compound 1; then compound 2; then compound 3.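

In this assay, the aromatic carbon that carries the 1-amino-2-methylbutyl group in compound 1 accepts the larger 1-(((aminomethyl)carbonyl)amino)-3-methylbutyl group with no loss of inhibition, giving a 3.9-fold lower number from compound 1 to compound 4 (0.60 log units; beyond the scatter). For the compounds shown here, this is the first single change read at this position, and it shows that the amine there can be extended into a longer side chain bearing a carbonyl and a second nitrogen while the number still falls. Nothing available explains this gain.

The change also moves the methyl branch along the butyl chain, so the compounds shown cannot separate that shift from the added aminomethylcarbonyl part. From the compounds shown here alone, whether the added amine matters also stays open, since neither a plain acetyl group on that nitrogen nor a longer aminoalkyl chain appears among them.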